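This account rests on a few compounds, and the source may have more. Where it says the series, first, only, none or still open, it means among the compounds named here.

Working notes on the series.

Compound 3 `CS(=O)(=O)Cc1cccc(C#Cc2cc(Cl)ccc2OCC(=O)O)c1` gives 48 nM in an assay on CHO cells for displacement of a labelled ligand from prostaglandin D2 receptor 2 (Homo sapiens), read by scintillation counting; a higher number here means a weaker inhibitor, a lower number a stronger inhibitor. Among the measured compounds shown here, on the numbers so far it stands second highest of three: its nearest neighbour is compound 1 `O=C(O)COc1ccc(Cl)cc1C#Cc1cccc(C(F)(F)F)c1`, which in this assay gives 92 nM, with the step of a 1.9-fold lower number from compound 1 to compound 3 (0.28 log units; within the scatter); its furthest is compound 2 `C[S+]([O-])c1cccc(C#Cc2cc(Cl)ccc2OCC(=O)O)c1`, which in this assay gives 3.2 nM, with the step of a 15-fold higher number from compound 2 to compound 3 (1.18 log units; beyond the scatter).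

Compound 4 `CS(=O)(=O)c1cccc(C#Cc2cc(Cl)ccc2OCC(=O)O)c1` has not yet been measured in this assay. It differs from compound 3 in one place: methylsulfonyl in place of (methylsulfonyl)methyl on an aromatic carbon.

For the measured compounds named here, two measured steps bear on this change. Replacing trifluoromethyl in compound 1 by (methylsulfonyl)methyl gave a 1.9-fold lower number from compound 1 to compound 3 (0.28 log units; within the scatter), a step within the scatter. Replacing the methylsulfinyl of compound 2 by (methylsulfonyl)methyl gave a 15-fold higher number from compound 2 to compound 3 (1.18 log units; beyond the scatter), a large step. The group entering in compound 4 sits on the aromatic carbon without the intervening carbon of the (methylsulfonyl)methyl group, and in that sense compound 4 is nearer in build to compound 2 than compound 3 is. A lower number than that of compound 3 is therefore expected, in the direction of compound 2, though not with confidence that the full step of a 15-fold higher number from compound 2 to compound 3 (1.18 log units; beyond the scatter) is recovered.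

Compound 4 is estimated at 8 nM in this assay, expected range 2 nM to 30 nM, an expected step of a 6.0-fold lower number from compound 3 to compound 4 (0.78 log units; beyond the scatter).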

Compound 4, inhibition constant: 15 nM
Estimate against measurement, compound 4: 1.9-fold (0.27 log units) below, within the range that was stated.
By their numbers in this assay, from the lowest: compound 2; then compound 4; then compounds 3 and 1 (each within the scatter of the next).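

Shortening (methylsulfonyl)methyl to methylsulfonyl on the aromatic carbon gives a 3.2-fold lower number from compound 3 to compound 4 (0.51 log units; beyond the scatter) in this assay, so with the two oxygens on sulfur kept, the carbon link alone moves the number beyond the scatter. Against trifluoromethyl, the directly attached methylsulfonyl gives a 6.1-fold lower number from compound 1 to compound 4 (0.79 log units; beyond the scatter), a separation that (methylsulfonyl)methyl did not achieve with a 1.9-fold lower number from compound 1 to compound 3 (0.28 log units; within the scatter), so the two sulfone-bearing groups differ in how they stand against trifluoromethyl at this position. The methylsulfinyl group still keeps its lead, with a 4.7-fold higher number from compound 2 to compound 4 (0.67 log units; beyond the scatter), so direct attachment of the sulfur does not by itself reach the number of compound 2, and the group on sulfur matters too.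

No measurement shown here gives a reason for any of these steps. Still open, going by these compounds, is how a methylthio group or a sulfonamide would stand on this aromatic carbon, and whether a longer chain such as 2-(methylsulfonyl)ethyl would continue the trend seen from methylsulfonyl to (methylsulfonyl)methyl.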